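The source may report more compounds than this note shows. Statements on the series, on what has been measured and on what is new or still open speak of the compounds shown alone.

Working notes on the series in a functional assay on HeLa cells (Homo sapiens) for inhibition, read by CCK-8 assay, with a stated time of 48 h; a lower number here means a stronger inhibitor, a higher number a weaker inhibitor. Compound 1 `COc1ccc(Oc2ccc([N+](=O)[O-])cc2-c2ccsc2S(=O)(=O)N2CCN(C(=O)Nc3ccc([N+](=O)[O-])cc3)CC2)cc1OC` reaches only a limit of the assay: in this assay compound 1 reads > 50000 nM. Compound 2 `Cc1ccc(-c2ccsc2S(=O)(=O)NCCNC(=O)Nc2cccc([N+](=O)[O-])c2)c(Oc2ccc(O)c(O)c2)c1` likewise reaches only a limit: in this assay compound 2 reads > 20000 nM. Both values shown are limits and not numbers, as the limit of > 20000 nM in this assay, at which 1 of the 2 values shown sits, and the limit of > 50000 nM in this assay, at which 1 of the 2 values shown sits, record, so compound 2 stands at a limit with no number of its own, and nothing in the two values sets an order between compound 1 and compound 2. Among the compounds with values here, no step between measured compounds can be counted.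

Compound 3 `Cc1ccc(-c2ccsc2S(=O)(=O)NCCNC(=O)Nc2cc(Cl)cc(Cl)c2)c(Oc2ccc(O)c(O)c2)c1` differs from compound 2 in one place (3,5-dichlorophenyl in place of 3-nitrophenyl on an amide-type nitrogen). With compound 2 at a limit, no measured step shows how a change on this amide-type nitrogen moves this assay, and the data give no reason to expect a gain. The step is expected to be a step that the limit leaves unreadable from compound 2 to compound 3, none beyond the usual scatter. For compound 3 the estimate in this assay is 30000 nM, within 8000 nM to 100000 nM, and most likely the result is again reported only as a limit.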

Compound 3, half-maximal inhibitory concentration: 6500 nM
For compound 3 the middle estimate is 4.6-fold (0.66 log units) above the measured one; the measured number lies below the stated range.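

The 3,5-dichlorophenyl group on the amide-type nitrogen gives the only reading among the compounds shown that is a number and not a limit, and in this assay the change shows an at least 3.0-fold lower number from compound 2 to compound 3 (0.48 log units; beyond the scatter), so this position can move the read-out, which the two limits alone could not show. The size of the step is only a minimum, as the starting point of compound 2 is a limit of the assay and not a number: the limit of > 20000 nM in this assay, at which 1 of the 3 values shown sits. The change replaces a group with hydrogen-bond acceptors by one with none, and this single pair cannot separate the loss of the nitro group from the arrival of the two chlorine atoms.

Still open, from the compounds shown here alone, is whether one chlorine atom is enough, as in 3-chlorophenyl, and how a trifluoromethyl group, an amine or a carboxylic acid on the same ring reads in this assay. Also open, going by these compounds, is whether the gain at this amide-type nitrogen holds with a longer chain on the sulfonamide side or with the ring-closed linker of compound 1.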